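The compounds below may be only part of what the source reports. "The series", "measured", "known", "first", "only" and "open" are said of these compounds alone.

Measured compounds:
compound 1 `Cc1cc(NC(=O)c2ccc(Cl)cc2)ccc1NS(C)(=O)=O` — 50300 nM
compound 2 `Cc1cc(NC(=O)c2cccc(C(F)(F)F)c2)ccc1NS(C)(=O)=O` — 194000 nM
compound 3 `COc1cc(NC(=O)c2ccc(Cl)cc2)ccc1NS(C)(=O)=O` — > 250000 nM

All three were tested in an ADME assay on HEK293 cells (Homo sapiens) for cytotoxicity, read by MTT assay, with a stated time of 48 h; on this read-out higher numbers stand for weaker inhibition and lower numbers for stronger inhibition. Compound 1 gives 50300 nM and compound 2 gives 194000 nM, the higher of the two numbers. Compound 3 gives > 250000 nM, which is a limit of the assay rather than a number. Compound 1 and compound 3 differ by one change, (methoxy in place of methyl on an aromatic carbon), and the step is an at least 4.9-fold higher number from compound 1 to compound 3 (0.69 log units; beyond the scatter); it is known only as a bound because of the limit of > 250000 nM in this assay, at which 1 of the 3 values shown sits. The difference between the cores of compound 1 and compound 2 is not broken down here. Compound 4 `COc1cc(NC(=O)c2cccc(C(F)(F)F)c2)ccc1NS(C)(=O)=O` has not yet been measured; it differs from compound 2 by the same change, (methoxy in place of methyl on an aromatic carbon). Set beside an at least 4.9-fold higher number from compound 1 to compound 3 (0.69 log units; beyond the scatter), the step from compound 2 is expected to be a 2.6-fold higher number from compound 2 to compound 4 (0.41 log units; beyond the scatter), which rests on that single measured step. Compound 4 is therefore estimated at 500000 nM, likely reaching the limit.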

Compound 4, half-maximal inhibitory concentration: > 250000 nM
Compound 4: no number, only a limit; the forecaster's own chance of this, stated with the estimate: 75%; the middle value is on the limit's open side.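

In this assay compound 4 gives > 250000 nM, which is a limit of the assay and not a number. Putting methoxy in place of methyl on this second core gives an at least 1.2-fold higher number from compound 2 to compound 4 (0.11 log units; that floor lies within the scatter), so the result does not go against the rise seen on the first core, but on its own it does not confirm a rise beyond the usual scatter. The size of the change therefore cannot be said to carry over from one core to the other, and neither can a difference between the cores be shown: the same change on two cores in this assay, an at least 4.9-fold higher number (0.69 log units; beyond the scatter) from compound 1 to compound 3 and an at least 1.2-fold higher number (0.11 log units; that floor lies within the scatter) from compound 2 to compound 4; the limit leaves it open whether they differ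

On these data alone, the true numbers for compound 3 and compound 4 remain open, as both are known only as limits. Also open, as far as these compounds go, is how an amine or a longer chain such as ethoxy would behave at this place on either core.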